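The source may hold more compounds than are shown below. What is called first, only, known or untested is meant among the compounds shown, and "the series" means these compounds.

Measured compounds in the series:

- compound 1, `O=S(=O)(NCCCNCc1ccc(Cl)c(Cl)c1)c1cc(C(F)(F)F)cc(C(F)(F)F)c1`, 5600 nM
- compound 2, `O=S(=O)(NCCCNCc1ccc(C(F)(F)F)cc1)c1cc(C(F)(F)F)cc(C(F)(F)F)c1`, 3200 nM
- compound 3, `O=S(=O)(NCCCNCc1ccc(Br)cc1)c1cc(C(F)(F)F)cc(C(F)(F)F)c1`, 2200 nM

All three share the same core and differ only in the aryl group on the saturated chain carbon bound to the amine nitrogen. In a functional assay on PANC-1 cells (Homo sapiens) for inhibition, read by MTT assay, with a stated time of 72 h (on this read-out lower numbers stand for stronger inhibition of growth and higher numbers for weaker inhibition of growth), compound 3 gives the lowest of the three numbers; its nearest neighbour is compound 2, and the gap between them, a 1.5-fold lower number from compound 2 to compound 3 (0.16 log units; within the scatter), is within the scatter, so no order between these two can be claimed. The gap to compound 1, a 2.5-fold lower number from compound 1 to compound 3 (0.41 log units; beyond the scatter), is beyond the scatter and modest.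

The next compound, compound 4, `O=S(=O)(NCCCNCc1cccc(Cl)c1)c1cc(C(F)(F)F)cc(C(F)(F)F)c1`, is built from compound 3 by the change (3-chlorophenyl in place of 4-bromophenyl on a saturated chain carbon bound to an amine nitrogen). Among the compounds with values here, two measured steps bear on this. The step of a 2.5-fold lower number from compound 1 to compound 3 (0.41 log units; beyond the scatter) shows that moving from two halogens on the ring to a single bromine lowered the number modestly; the step of a 1.5-fold lower number from compound 2 to compound 3 (0.16 log units; within the scatter) shows that swapping one single para-type substituent for another changed nothing beyond the scatter. Compound 4 keeps a single halogen but moves it, so the expectation is a small step, if any, and rather toward a higher number than a lower one, since compound 1, which carries a chloro at that ring position together with a second one, gave 5600 nM.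

The estimate for compound 4 in this assay is 3000 nM, with a range of 1500 nM to 6500 nM, corresponding to an expected step of a 1.4-fold higher number from compound 3 to compound 4 (0.13 log units; within the scatter).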

Compound 4, concentration for 50% growth inhibition: 12000 nM
Beside the measured number, compound 4's estimate is 4.0-fold (0.60 log units) below it; measured number above the stated range.
By their numbers in this assay, from the lowest: compounds 3, 2 and 1 (each within the scatter of the next, the first and the last beyond it); then compound 4.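

In this assay, the aryl group on the saturated chain carbon bound to an amine nitrogen now shows a clear dependence on which single substituent it carries: 3-chlorophenyl gives a 5.5-fold higher number from compound 3 to compound 4 (0.74 log units; beyond the scatter), and against 4-(trifluoromethyl)phenyl it gives a 3.8-fold higher number from compound 2 to compound 4 (0.57 log units; beyond the scatter). The number of halogens alone therefore does not set the order, as taking away one chloro from the 3,4-dichlorophenyl group, with hydrogen in its place on an aromatic carbon, gives a 2.1-fold higher number from compound 1 to compound 4 (0.33 log units; beyond the scatter) rather than the lower number that compound 3, also with a single halogen, might have suggested. Among these four compounds, all three with a group named at the 4 position of the ring give lower numbers than compound 4, but no measurement at hand accounts for these steps.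

The step from 4-bromophenyl to 3-chlorophenyl changes both the halogen and its ring position, so the two contributions cannot be separated here; 4-chlorophenyl or 3-bromophenyl would divide them. On these data alone, whether a methoxy group or a nitrile on the ring, or a longer chain in the linker, would hold the lower numbers also remains open.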